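Carbamoylamino Replaces Hydrogen on the Amide Side Chain

The source may hold more compounds than are shown below. What is called first, only, known or untested is meant among the compounds shown, and "the series" means these compounds.

Compound 1 `O=C(O)CCNC(=O)c1ccc2c(c1)C(=O)N(CCC1CCNCC1)C2`: 27 nM
Compound 2 `CC(C)CS(=O)(=O)N[C@@H](CNC(=O)c1ccc2c(c1)C(=O)N(CCC1CCNCC1)C2)C(=O)O`: 9 nM

Within the data shown here, in a functional assay for inhibition, with Homo sapiens as the target (on this read-out higher numbers stand for weaker inhibition and lower numbers for stronger inhibition), compound 1 gives 27 nM, the highest of the two numbers so far, with compound 2 nearest to it. Compound 3 `O=C(NCc1ccccc1)N[C@@H](CNC(=O)c1ccc2c(c1)C(=O)N(CCC1CCNCC1)C2)C(=O)O` carries (benzylcarbamoyl)amino in place of hydrogen on a saturated chain carbon bound to a carbonyl carbon and a saturated chain carbon. Among the measured compounds shown here, the only step that bears on this change is a 3.0-fold lower number from compound 1 to compound 2 (0.48 log units; beyond the scatter), which also places a group at the same position on the chain. A lowering of similar, modest size is therefore expected for compound 3: a 2.3-fold lower number from compound 1 to compound 3 (0.35 log units; beyond the scatter). Compound 3 is estimated to give about 12 nM, within a range from 4 nM to 40 nM.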

Compound 3, half-maximal inhibitory concentration: 10 nM
Beside the measured number, compound 3's estimate is 1.2-fold (0.08 log units) above it, and the stated range covers the measured number.
By their numbers in this assay, from the lowest: compounds 2 and 3 (each within the scatter of the next); then compound 1.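

At this saturated chain carbon, a second and quite different group also lowers the number in this assay: (benzylcarbamoyl)amino in place of hydrogen gives a 2.7-fold lower number from compound 1 to compound 3 (0.43 log units; beyond the scatter), so the earlier drop is not unique to the sulfonyl compound. Benzylcarbamoyl in place of isobutylsulfonyl on the amine nitrogen gives a 1.1-fold higher number from compound 2 to compound 3 (0.05 log units; within the scatter), so the two groups cannot be told apart in this read-out. No measurement here explains why either group lowers the number.

On these data alone, it remains open whether a free amine on this carbon would already lower the number, and whether a smaller acetyl group on that nitrogen would match benzylcarbamoyl.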